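A few compounds are considered here, and "the series" means these few. Any claim that something is new, unique, unknown or untested is made for them only; others in the source may bear on it.

Measured compounds:
compound 1 `COc1ccc(OC)c(S(=O)(=O)NC(=O)c2ccc(Cn3ccc4ccc(NC(=O)CC5CCCC5)cc43)c(OC)c2)c1` — 9.1
compound 2 `COc1cc(-c2nn[nH]n2)ccc1Cn1ncc2ccc(NC(=O)OC3CCCC3)cc21` — 7.7

Of the compounds shown here, two have been measured in a functional assay (trachea) for antagonist activity, with Cavia porcellus as the target; a lower number here means a less potent compound, a higher number a more potent compound, by a factor of ten per unit of this negative logarithm. Compound 1 gives 9.1, the higher of the two numbers, and compound 2 gives 7.7, a gap that lies beyond the usual scatter. Since the two structures differ in several places at once, that gap says nothing about any single change.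

The unmeasured compound 3 `COc1cc(C(=O)NS(=O)(=O)c2cc(C)ccc2C)ccc1Cn1ccc2ccc(NC(=O)CC3CCCC3)cc21` keeps the shared core of compound 1 and alters only the group on the sulfonyl sulfur, whose other neighbour is an amide-type nitrogen: 2,5-dimethylphenyl in place of 2,5-dimethoxyphenyl on a sulfonyl sulfur. The swap removes the two oxygen atoms of the methoxy groups and keeps the ring and its two substituent positions. Among the measured compounds shown here, no measured pair isolates this kind of change, so there is no direct guide to its size.

With the rest of the molecule unchanged, compound 3 is expected to stay close to compound 1, and the step from a number 0.30 log units lower from compound 1 to compound 3 (within the scatter) is estimated to be small and slightly downward, within or near the scatter. The estimate for compound 3 in this assay is 8.8, with a range from 8.2 to 9.4.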

Compound 3, negative logarithm of the antagonist equilibrium constant: 8.4
The estimate for compound 3 lay 0.40 log units above the measured number; measured number inside the range.
By their numbers in this assay, from the lowest: compound 2; then compound 3; then compound 1.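

In this assay, among the compounds shown here, putting 2,5-dimethylphenyl in place of 2,5-dimethoxyphenyl on the sulfonyl sulfur gives a number 0.70 log units lower from compound 1 to compound 3 (beyond the scatter) and is the first change here that can be read on its own. The group on this sulfur therefore matters for potency: the ring and its two substituent positions stay, the two oxygen atoms of the methoxy groups go, and the step is modest but larger than ordinary repeat-to-repeat variation. No measurement at hand gives a reason for this loss of potency.

Both methoxy groups change together in this single step, which leaves open whether one of them alone accounts for the difference or both contribute. Also open, on these data alone, is how far this position tolerates other groups on the sulfonyl sulfur, such as an unsubstituted phenyl ring, a 2,5-dichlorophenyl ring or an open pentyl chain, and whether any of these would come closer to compound 1 or fall further away.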